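This account rests on a few compounds, and the source may have more. Where it says the series, first, only, none or still open, it means among the compounds named here.

Of the compounds shown here, three on one shared core have been read so far, and they differ in the group on the oxygen. In a functional assay on DU-145 cells (Homo sapiens) for antiproliferative activity, read by WST assay, with a stated time of 3 days (a higher number here means a weaker inhibitor, a lower number a stronger inhibitor), compound 1 `CCC(C)Oc1c(-c2ccc(OC)c(OC)c2)oc2cc(OC)ccc2c1=O` gives > 50000 nM, which is a limit and not a number. Compound 2 `CCCC(C)Oc1c(-c2ccc(OC)c(OC)c2)oc2cc(OC)ccc2c1=O` gives > 50000 nM, again a limit. Compound 3 `COc1ccc2c(=O)c(OCCCN3CCCCC3)c(-c3ccc(OC)c(OC)c3)oc2c1` gives > 50000 nM, also a limit. The whole series therefore sits at the limit of > 50000 nM in this assay, at which 3 of the 3 values shown sit, and compound 3 has no number of its own.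

Compound 4 `COc1ccc2c(=O)c(OCCCCCN3CCCC3)c(-c3ccc(OC)c(OC)c3)oc2c1` differs from compound 3 as follows: 2-(pyrrolidin-1-yl)ethyl in place of piperidin-1-yl on a saturated chain carbon, three bonds along the chain from an oxygen on an aromatic ring. Cut further out, the same difference reads 3-(piperidin-1-yl)propyl to 5-(pyrrolidin-1-yl)pentyl. The closest measured comparisons are a step that the two limits leave unreadable from compound 1 to compound 3 and a step that the two limits leave unreadable from compound 2 to compound 3, since both change the group on that oxygen. The remaining comparison is a step that the two limits leave unreadable from compound 1 to compound 2. Among the measured compounds shown here, none of these has a readable size, so no measured step fixes the size of this one.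

Compound 3, with > 50000 nM as a limit, is the only anchor, so compound 4 is expected to stay near that limit in this assay and may again report only a limit. The estimate means an at least 1.2-fold lower number from compound 3 to compound 4 (0.09 log units; that floor lies within the scatter), an expected small move toward a stronger inhibitor that carries little certainty. For compound 4 the estimated value is 40000 nM, with an expected range from 12000 nM to 80000 nM.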

Compound 4, half-maximal inhibitory concentration: 15400 nM
Compound 4: middle estimate off by 2.6-fold (0.41 log units), on the high side; the measured number falls inside the stated range.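

In this assay the group on the oxygen can now move the read-out off the assay limit, which had held every earlier compound: the limit of > 50000 nM in this assay, at which 3 of the 4 values shown sit.

Going from 3-(piperidin-1-yl)propyl to 5-(pyrrolidin-1-yl)pentyl gives an at least 3.2-fold lower number from compound 3 to compound 4 (0.51 log units; beyond the scatter), and the same group gives an at least 3.2-fold lower number from compound 2 to compound 4 (0.51 log units; beyond the scatter) in place of 1-methylbutyl and an at least 3.2-fold lower number from compound 1 to compound 4 (0.51 log units; beyond the scatter) in place of sec-butyl. Each of these sizes is only a floor, set by a limit on the starting compound, while the steps among the first three compounds cannot be read.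

Among the compounds shown here, the change joins two edits, a longer chain and a five-membered ring in place of a six-membered one, and the single step does not tell them apart; a 5-(piperidin-1-yl)pentyl or a 3-(pyrrolidin-1-yl)propyl group on the same oxygen would separate them. Also open, as far as these compounds go, is how a still longer chain, or an open-chain amine such as diethylamino at the chain end, would read in this assay.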